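Thioether side chain swap at the shared core

A few compounds are considered here, and "the series" means these few. Any claim that something is new, unique, unknown or untested is made for them only; others in the source may bear on it.

Compound 1 `CC(C(=O)NCc1ccc(C(F)(F)F)nc1SCCCN1CCCCC1)c1ccc(NS(C)(=O)=O)c(F)c1` is the reference point of the series. Among the measured compounds shown here, in an assay on CHO-K1 cells for antagonist activity at transient receptor potential cation channel subfamily V member 1 (Homo sapiens), read by FLIPR (a higher number here means a weaker inhibitor, a lower number a stronger inhibitor), compound 1 gives 3 nM, the only number recorded so far. Compound 2 `CC(C(=O)NCc1ccc(C(F)(F)F)nc1[S+]([O-])C1CCCCC1)c1ccc(NS(C)(=O)=O)c(F)c1` carries a different sulfur group and a different ring on the shared core; in this assay compound 2 is reported as "not active" (no number reported), without a number, so no comparison of size can be drawn between compound 1 and compound 2.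

Compound 3 `COc1ccc(CSc2nc(C(F)(F)F)ccc2CNC(=O)C(C)c2ccc(NS(C)(=O)=O)c(F)c2)cc1` keeps the shared core of compound 1 and changes only the chain on the sulfur: 4-methoxyphenyl in place of 2-(piperidin-1-yl)ethyl on a saturated chain carbon bound to a sulfur. For the measured compounds named here, no measured pair in the set isolates this kind of change, so the expected size of the step rests on the single value of compound 1 alone.

The expectation is a moderate loss beyond the scatter, since the group that leaves and the group that enters are of equal size but of different character, and the step from compound 1 to compound 3 is estimated as a 5.0-fold higher number from compound 1 to compound 3 (0.70 log units; beyond the scatter). For compound 3 the estimated value in this assay is 15 nM, with a range from 3 nM to 80 nM.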

Compound 3, inhibition constant: 2.3 nM
Estimate against measurement, compound 3: 6.5-fold (0.81 log units) above, and the stated range ends above it.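

Among the compounds shown here, exchanging 2-(piperidin-1-yl)ethyl for 4-methoxyphenyl on a saturated chain carbon bound to a sulfur gives a 1.3-fold lower number from compound 1 to compound 3 (0.12 log units; within the scatter) in this assay, the first readable step. The two compounds cannot be told apart in this assay, so a number in this range does not depend on the piperidine ring or its nitrogen: the group in compound 3 holds a six-membered aromatic ring of carbon only and an oxygen, yet the read-out stays within the scatter of compound 1. No measured data are available to explain why these two different groups give equivalent values.

As far as these compounds go, compound 2 differs from compound 1 in both its sulfur group and its ring and has no number, so its steps cannot be read, and it remains open which of the two changes goes with the "not active" report. Also open, from the compounds shown here alone, is how far this tolerance extends, for example whether a carboxylic acid-bearing chain or a morpholine ring in place of the 4-methoxybenzyl group would keep a value of this order.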